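This account rests on a few compounds, and the source may have more. Where it says the series, first, only, none or still open, it means among the compounds named here.

Measured so far in a functional assay on PC-3 cells (Homo sapiens) for cytotoxicity, read by MTT assay, with a stated time of 72 h; a lower number here means a stronger inhibitor, a higher number a weaker inhibitor:
- compound 1 `CNC(=O)c1cc(Oc2ccc(C3=NNC(c4ccc(C#N)cc4)C3)cc2)ccn1` gives 9910 nM
- compound 2 `CNC(=O)c1cc(Oc2ccc(C3=NNC(c4cccc([N+](=O)[O-])c4)C3)cc2)ccn1` gives "not determined" (no result reported)

Compound 2 has no place on the scale of this assay. Its entry reads "not determined" (no result reported) and carries no number, so it cannot be ranked against compound 1, which stands alone at 9910 nM as the only measured reference.

The next compound to be tested is compound 3 `CNC(=O)c1cc(Oc2ccc(C3=NNC(c4ccc(OC)cc4)C3)cc2)ccn1`, which differs from compound 2 in a single place: 4-methoxyphenyl in place of 3-nitrophenyl on a saturated ring carbon. This puts 4-methoxyphenyl in place of 3-nitrophenyl on a saturated ring carbon, while the rest of the structure stays the same.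

Within the data shown here, no measured step is available for this series, so the data do not show what such an exchange does. Without a number for compound 2, no direction can be expected for the step from it. The expectation therefore rests on compound 1 at 9910 nM in this assay, and compound 3 is expected to lie near that value, with no difference beyond the usual scatter. For compound 3 the estimated value is 9000 nM, with an expected range from 3000 nM to 27000 nM.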

Compound 3, half-maximal inhibitory concentration: 7740 nM
The estimate for compound 3 lay 1.2-fold (0.07 log units) above the measured number; low and high end bracket the measured number.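

In this assay, among these compounds, putting methoxy in place of the nitrile on an aromatic carbon gives a 1.3-fold lower number from compound 1 to compound 3 (0.11 log units; within the scatter), the first step that can be read, so two different groups on this aromatic carbon of the phenyl ring can now be compared, and they cannot be told apart in this assay. The step between compound 2 and compound 3 cannot be read, as compound 2 has no number, so the exchange of 3-nitrophenyl for 4-methoxyphenyl on the saturated ring carbon tells nothing. No supporting measurement is available that would explain why the nitrile and methoxy compounds fall so close together.

The compounds shown leave open whether any group on this phenyl ring can move the number in this assay beyond the scatter, for example an amine or a carboxylic acid on the same aromatic carbon, or a longer chain such as butoxy in place of methoxy. They also leave open whether a group on a different carbon of the phenyl ring, as in the 3-nitrophenyl of compound 2, would give a number different from those of compound 1 and compound 3.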